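Shortening the sulfur-bound chain in a cytotoxicity series

A few compounds are considered here, and "the series" means these few. Any claim that something is new, unique, unknown or untested is made for them only; others in the source may bear on it.

The three measured compounds share one core and differ only in the group on one aromatic carbon. Compound 1 `CC(C)CSc1nc(N)nc2c1ncn2/C=C1/CC1(CO)CO` carries an isobutylsulfanyl group there, compound 2 `Nc1nc(N2CCCC2)c2ncn(/C=C3/CC3(CO)CO)c2n1` a pyrrolidin-1-yl group, and compound 3 `CCCCCCCCSc1nc(N)nc2c1ncn2/C=C1/CC1(CO)CO` an octylsulfanyl group. In an ADME assay on Akata cells (Homo sapiens) for cytotoxicity, with a stated time of 7 days (a higher number here means that more compound is tolerated, a lower number that less compound is tolerated), compound 1 gives > 20000 nM, which is a limit of the assay rather than a number. Compound 2 likewise reaches only a limit in this assay, at > 24000 nM. Compound 3 too gives only a limit in this assay, namely > 20000 nM. Two of the three values sit at the limit of > 20000 nM in this assay, at which 2 of the 3 values shown sit, and one at the limit of > 24000 nM in this assay, at which 1 of the 3 values shown sits, so compound 3 stands nowhere more precise than at a limit. None of the three steps between them can be read: a step that the two limits leave unreadable from compound 1 to compound 2, a step that the two limits leave unreadable from compound 1 to compound 3 and a step that the two limits leave unreadable from compound 2 to compound 3.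

Compound 4 `CCCCSc1nc(N)nc2c1ncn2/C=C1/CC1(CO)CO` differs from compound 3 by one change: hydrogen in place of butyl on a saturated chain carbon, four bonds along the chain from a sulfur. Within the data shown here, the only measured step that also alters the chain bound to the sulfur is the one from compound 1 to compound 3, and it is unreadable, so no readable step bears on this change. No step beyond the scatter is expected in this assay. Compound 4 is therefore expected to give about 25000 nM in this assay, within 15000 nM to 60000 nM, most probably again only as a limit. This expectation corresponds to an estimated step that the limit leaves unreadable from compound 3 to compound 4.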

Compound 4, half-maximal cytotoxic concentration: > 20000 nM
Compound 4 ended at the assay's limit (the forecaster's own chance of this, stated with the estimate: 85%); the middle value lies beyond the limit too.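

In this assay compound 4 gives > 20000 nM, which is a limit and not a number. The steps to compound 4 from compound 1, compound 2 and compound 3 cannot be read. The compounds shown leave open whether changing the group on that aromatic carbon alters cytotoxicity at all.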